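A few compounds are considered here, and "the series" means these few. Any claim that something is new, unique, unknown or untested is made for them only; others in the source may bear on it.

Compound 3 `CC(C)OC(=O)N1CCC2(CC1)CC(CCCOc1ccc(S(C)(=O)=O)c(F)c1)C2` gives 18 nM in a functional assay on cells for agonist activity at Glucose-dependent insulinotropic receptor (Homo sapiens), read by HTRF and cAMP accumulation, with a stated time of 30 min (a lower number here means that less compound is needed, a higher number that more compound is needed for the effect), and sits second highest of the three numbers. Its nearest neighbour is compound 1 `CC(C)(C)OC(=O)N1CCC2(CC1)CC(CCCOc1ccc(S(C)(=O)=O)c(F)c1)C2`, which gives 9 nM; the step of a 2.0-fold higher number from compound 1 to compound 3 (0.30 log units; within the scatter) lies within the scatter. Compound 2 `CC(C)OC(=O)N1CCC2(CC1)CC(CCCOc1ccc(S(C)(=O)=O)cc1)C2` gives 78 nM, and the step of a 4.3-fold lower number from compound 2 to compound 3 (0.64 log units; beyond the scatter) is modest but beyond the scatter. Compound 4 `CC1(OC(=O)N2CCC3(CC2)CC(CCCOc2ccc(S(C)(=O)=O)c(F)c2)C3)CC1` carries 1-methylcyclopropyl in place of isopropyl on an oxygen next to a carbonyl group. Within the data shown here, the only measured step at that oxygen, a 2.0-fold higher number from compound 1 to compound 3 (0.30 log units; within the scatter), was within the scatter, so the change to a 1-methylcyclopropyl group is expected to move the number little, if at all toward the lower value of compound 1. The estimated step is a 1.5-fold lower number from compound 3 to compound 4 (0.18 log units; within the scatter), also within the scatter. Compound 4 is therefore expected to give 12 nM, with a range from 5 nM to 30 nM.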

Compound 4, half-maximal effective concentration: 13 nM
Estimate against measurement, compound 4: 1.1-fold (0.03 log units) below; measured number inside the range.
By their numbers in this assay, from the lowest: compounds 1, 4 and 3 (each within the scatter of the next); then compound 2.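

In this assay the 1-methylcyclopropyl group on an oxygen next to a carbonyl group reads level with both ring-free groups, with a 1.4-fold lower number from compound 3 to compound 4 (0.14 log units; within the scatter) and a 1.4-fold higher number from compound 1 to compound 4 (0.16 log units; within the scatter) as the two steps. A three-membered non-aromatic ring is thus accepted at this position without a step beyond the scatter, and isopropyl, tert-butyl and 1-methylcyclopropyl now all lie within the scatter of one another. Nothing measured here gives a reason for this flat reading. Still open, going by these compounds, is whether a cyclobutyl or phenyl group on that oxygen would stay as level. Also open, on these data alone, is whether the fluoro step seen with isopropyl carries over to 1-methylcyclopropyl.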